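This account rests on a few compounds, and the source may have more. Where it says the series, first, only, none or still open, it means among the compounds named here.

Measured so far:
- compound 1 `CCCCn1c(S)nnc1COc1ccc(-c2ccccc2)cc1` — 75%
- compound 2 `Fc1ccc(-n2c(S)nnc2COc2ccc(-c3ccccc3)cc2)cc1` — 75%

Notes. In a functional assay on the whole organism (strain Wistar) for inhibition, with Rattus norvegicus as the target, read by paw edema, with a stated time of 3 h, at a dose of 10 mg/kg by the oral route (on this read-out lower numbers stand for less inhibition and higher numbers for more inhibition at the one dose given (going by the name of the read-out)), compound 1 gives 75%, and compound 2 gives 75%. Within the data shown here, the one step available is no change at the digits printed from compound 1 to compound 2 (within the scatter), which swaps an alkyl chain for an aromatic ring on the ring nitrogen of the shared core without moving the read-out. On these numbers compound 2 stands level with compound 1; nothing in the pair separates the two.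

Next in line is compound 3 `Cc1ccccc1-n1c(S)nnc1COc1ccc(-c2ccccc2)cc1`. The change from compound 2 is 2-methylphenyl in place of 4-fluorophenyl on an aromatic nitrogen. Among the measured compounds shown here, the only measured step that speaks to this position is the one from compound 1 to compound 2, and it was flat within the scatter even though the group on that nitrogen was replaced outright. Here the group stays an aromatic ring of the same size and the substituent on it merely moves and changes identity, so no step beyond the scatter is expected in this assay, which would mean no change at the digits printed from compound 2 to compound 3 (within the scatter). For compound 3 the expected value is therefore 75%, with a range of 62% to 86%.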

Compound 3, a percentage reported as inhibition, in the whole organism at one dose (the size of the read-out at that dose, not a potency): 56.8%
Estimate against measurement, compound 3: 18.2 percentage points above; the measured number lies below the stated range.
By their numbers in this assay, from the lowest: compound 3; then compounds 1 and 2 (each within the scatter of the next).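

In this assay, the group on the aromatic nitrogen turns out not to be indifferent: the earlier replacement of butyl by 4-fluorophenyl gave no change at the digits printed from compound 1 to compound 2 (within the scatter), whereas 2-methylphenyl gives a number 18.2 percentage points lower from compound 2 to compound 3 (beyond the scatter) and a number 18.2 percentage points lower from compound 1 to compound 3 (beyond the scatter). Having a six-membered aromatic ring of carbon only on this nitrogen is therefore not enough to hold the read-out, since compound 2 and compound 3 both carry such a ring and still differ beyond the scatter, with compound 3 lying under both earlier compounds. No measurement bears on the reason for this drop.

Between compound 2 and compound 3 the substituent on the phenyl ring changes both its identity and its place, so these compounds cannot separate the effect of swapping fluorine for methyl from the effect of moving the substituent. From the compounds shown here alone, how a plain phenyl, a benzyl or a chain longer than butyl would read on this nitrogen stays open, as does the effect of replacing the sulfanyl group with a methyl or an amine.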